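The source may hold more compounds than are shown below. What is called first, only, known or untested is meant among the compounds shown, and "the series" means these compounds.

Measured so far in a functional assay on the whole organism (Tail, strain ICR) with Mus musculus as the target, in the tail flick test, with a stated time of 120 min, at a dose of 25 umol/kg by the oral route; on this read-out higher numbers stand for a stronger effect at the one dose given and lower numbers for a weaker effect:
compound 1 `O=C(CN(c1ncnc2c1ncn2C1CCCCO1)C1CC1)N[C@@H](CCC(=O)OCc1ccccc1)C(=O)OCc1ccccc1` gives 20.7%
compound 2 `CC[C@H](C)[C@H](NC(=O)CN(c1nc(Cl)nc2[nH]cnc12)C1CC1)C(=O)O` gives 21.4%

Compound 1 carries the lower of the two numbers, but compound 2 lies within the usual scatter of it, so the two readings are not separable. Going by the values given here, no single-change step between measured compounds is available, so the size of any step here has to be guessed.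

Compound 3 `O=C(CN(c1ncnc2c1ncn2C1CCCCO1)C1CC1)N[C@@H](CC(=O)OCc1ccccc1)C(=O)OCc1ccccc1` differs from compound 1 by benzyloxycarbonyl in place of (benzyloxycarbonyl)methyl on a saturated chain carbon, two bonds along the chain from an amide-type nitrogen and a carbonyl carbon. Without a measured step of this kind to lean on, the step from compound 1 to compound 3 is expected to stay within the scatter, a number 0.7 percentage points lower from compound 1 to compound 3 (within the scatter), with no direction claimed. Compound 3 is therefore estimated at 20%, in the range 8% to 35%.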

Compound 3, a percentage reported as activity, at one dose (the size of the read-out at that dose, not a potency): 7.82%
Estimate against measurement, compound 3: 12.2 percentage points above, outside the stated range (below it).
By their numbers in this assay, from the lowest: compound 3; then compounds 1 and 2 (each within the scatter of the next).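

In this assay, going by these compounds alone, the change to (benzyloxycarbonyl)methyl from 2-(benzyloxycarbonyl)ethyl gives a number 12.9 percentage points lower from compound 1 to compound 3 (beyond the scatter) and is the first single-change step. At this saturated chain carbon, the shorter chain therefore goes with the weaker effect at the one dose given, a reading that rests on this one pair. No measured evidence bears on this step.

Going by these compounds, whether a longer chain carrying benzyloxycarbonyl would raise the number remains open. So does the effect of an amine at the end of this chain in place of benzyloxycarbonyl.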